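From 3-Chlorobenzyl to 4-Fluorobenzyl in a Cytotoxicity Series

The compounds below may be only part of what the source reports. "The series", "measured", "known", "first", "only" and "open" are said of these compounds alone.

In a functional assay on 4T1 cells (Mus musculus) for cytotoxicity, read by MTT assay, with a stated time of 24 h (on this read-out higher numbers stand for weaker inhibition and lower numbers for stronger inhibition), compound 1 (`COc1ccc(/C=C2\CN(Cc3cn(Cc4cccc(Cl)c4)nn3)C/C(=C\c3ccc(OC)cc3)C2=O)cc1`) gives 56600 nM as its half-maximal inhibitory concentration. Compound 2 (`Cc1ccc(/C=C2\CN(C(=S)SCc3cn(Cc4cccc(Cl)c4)nn3)C/C(=C\c3ccc(C)cc3)C2=O)cc1`) gives 53400 nM on the same read-out, and compound 3 (`O=C1/C(=C/c2ccccc2F)CN(C(=S)SCc2cn(Cc3ccccc3F)nn2)C/C1=C\c1ccccc1F`) gives 30700 nM there too. Compound 1 therefore stands within the usual scatter of both other compounds, and the three numbers cannot be ranked.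

Compound 4 (`COc1ccc(/C=C2\CN(Cc3cn(Cc4ccc(F)cc4)nn3)C/C(=C\c3ccc(OC)cc3)C2=O)cc1`) differs from compound 1 in one place (4-fluorophenyl in place of 3-chlorophenyl on a saturated chain carbon bound to an aromatic nitrogen), with 4-fluorophenyl in place of 3-chlorophenyl on a saturated chain carbon bound to an aromatic nitrogen. Among the measured compounds shown here, no measured pair isolates this change, so the evidence is indirect. Compound 3, which also carries a fluorobenzyl group, stands at 30700 nM within the scatter of compound 1 at 56600 nM and offers no sign of a large shift, although it differs from compound 1 in more than one place.

In this assay the estimated step of a 1.3-fold lower number from compound 1 to compound 4 (0.10 log units; within the scatter) is expected to stay within the scatter. Compound 4 is estimated at 45000 nM with an expected range from 22000 nM to 90000 nM on that reasoning.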

Compound 4, half-maximal inhibitory concentration: 49300 nM
The estimate for compound 4 lay 1.1-fold (0.04 log units) below the measured number; measured number inside the range.
By their numbers in this assay, from the lowest: compounds 3, 4, 2 and 1 (each within the scatter of the next).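

Among the compounds shown here, the pair of compound 1 and compound 4 isolates this change for the first time: in this assay, replacing 3-chlorophenyl with 4-fluorophenyl on a saturated chain carbon bound to an aromatic nitrogen gives a 1.1-fold lower number from compound 1 to compound 4 (0.06 log units; within the scatter). Compound 3 could offer only an indirect hint, as it differs from compound 1 in more than one place, whereas here the rest of the structure stays the same. So this exchange of one halogen-bearing phenyl group for another leaves the cytotoxicity read-out unresolved from that of compound 1, and nothing available here bears on why.

The compounds shown leave open whether an aminophenyl group, a carboxyphenyl group or a longer chain at this place would move the number beyond the scatter. They also leave open whether the same exchange would behave alike on the core of compound 2.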